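The source may report more compounds than this note shows. Statements on the series, on what has been measured and on what is new or still open speak of the compounds shown alone.

Within the data shown here, compound 2 `COc1cc(-c2nn(-c3ccc(NC(=O)Nc4ccc(Cl)c(C(F)(F)F)c4)cc3)cc2-c2ccncc2)ccc1Cl` in a functional assay on LOX IMVI cells (Homo sapiens) for antiproliferative activity, read by sulforhodamine B assay, with a stated time of 48 h (a lower number here means a stronger inhibitor, a higher number a weaker inhibitor), gives 1430 nM, the lowest of the three numbers measured so far, though neither gap is beyond the scatter. Compound 1 `COc1cc(-c2nn(-c3ccc(NC(=O)Nc4ccc(Cl)c(Cl)c4)cc3)cc2-c2ccncc2)ccc1Cl` gives 1980 nM, and compound 3 `COc1cc(-c2nn(-c3ccc(NC(=O)Nc4cc(C(F)(F)F)cc(C(F)(F)F)c4)cc3)cc2-c2ccncc2)ccc1Cl` gives 1630 nM. Among the measured compounds shown here, the only single-point step among them, a 1.4-fold lower number from compound 1 to compound 2 (0.14 log units; within the scatter), shows that exchanging one substituent on the distal ring left the readout essentially unchanged.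

Compound 4 `COc1cc(-c2nn(-c3ccc(NC(=O)c4cc(Cl)cc(Cl)c4)cc3)cc2-c2ccncc2)ccc1Cl` differs from compound 2 by 3,5-dichlorophenyl in place of (4-chloro-3-(trifluoromethyl)phenyl)amino on a carbonyl carbon. For the measured compounds named here, this exchange removes the amino link of the urea and alters the substitution pattern of the distal ring at the same time, so no measured step bears on it directly; the one step available concerns only substituents on that ring and was within the scatter. Compound 4 is therefore expected to give a number in this assay close to that of compound 2, with a wide margin for the untested part of the change, a step of a 1.7-fold higher number from compound 2 to compound 4 (0.24 log units; within the scatter). The estimate for compound 4 is 2500 nM, ranging from 800 nM to 8000 nM.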

Compound 4, half-maximal inhibitory concentration: 3090 nM
Estimate against measurement, compound 4: 1.2-fold (0.09 log units) below; measured number inside the range.
By their numbers in this assay, from the lowest: compounds 2, 3, 1 and 4 (each within the scatter of the next, the first and the last beyond it).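

In this assay, among these compounds, putting 3,5-dichlorophenyl on the carbonyl carbon in place of (4-chloro-3-(trifluoromethyl)phenyl)amino gives a 2.2-fold higher number from compound 2 to compound 4 (0.33 log units; beyond the scatter), a modest step and the first single-place change to pass beyond the scatter. The same kind of exchange, starting from (3,4-dichlorophenyl)amino, gives a 1.6-fold higher number from compound 1 to compound 4 (0.19 log units; within the scatter), so losing the amino link does not clearly weaken the compounds from both starting points, and the size of the step depends on the group replaced. No measured evidence accounts for this difference.

The amino link and the ring substituents change together in both steps, so the compounds shown leave open how much of the change belongs to each. They also leave open how a methylene or an ether oxygen would compare with the amino link on the carbonyl carbon.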